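Aryl swap on the ring nitrogen: compound 3 to compound 4

The source may hold more compounds than are shown below. What is called first, only, known or untested is meant among the compounds shown, and "the series" means these compounds.

Measured compounds:
compound 1 `CNC(=O)c1cc(Oc2ccc(NC(=O)c3cc4cccnc4n(-c4ccccc4F)c3=O)cc2)ccn1` — 260 nM
compound 2 `CNC(=O)c1cc(Oc2ccc(NC(=O)c3cc4cccnc4n(-c4ccc(Cl)cc4)c3=O)cc2)ccn1` — 390 nM
compound 3 `CCNC(=O)c1cc(Oc2ccc(NC(=O)c3cc4cccnc4n(-c4ccccc4F)c3=O)cc2)ccn1` — 260 nM

All three were run in a functional assay on HT-29 cells (Homo sapiens) for antiproliferative activity, read by MTT assay, with a stated time of 72 h; a lower number here means a stronger inhibitor, a higher number a weaker inhibitor. Compound 3 stands level with compound 1 at the digits shown, the pair being the lowest two numbers of the three; the step of no change at the digits printed from compound 1 to compound 3 (within the scatter) is within the scatter, and compound 2 sits only a 1.5-fold higher number from compound 1 to compound 2 (0.18 log units; within the scatter) away, also within the scatter. Compound 4 `CCNC(=O)c1cc(Oc2ccc(NC(=O)c3cc4cccnc4n(-c4ccc(OC)cc4)c3=O)cc2)ccn1` is not yet measured. It differs from compound 3 in one place: 4-methoxyphenyl in place of 2-fluorophenyl on an aromatic nitrogen. Among the measured compounds shown here, the only measured step that bears on this kind of change is a 1.5-fold higher number from compound 1 to compound 2 (0.18 log units; within the scatter), an aryl-for-aryl exchange on the same aromatic nitrogen, which moved the number by less than the scatter. On that basis the expected step of a 1.2-fold higher number from compound 3 to compound 4 (0.09 log units; within the scatter) is small, at most a slight rise, and not clearly beyond the scatter. Compound 4 is therefore estimated at 320 nM, with a range from 150 nM to 700 nM.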

Compound 4, half-maximal inhibitory concentration: 3350 nM
For compound 4 the middle estimate is 10-fold (1.02 log units) below the measured one; the whole stated range lies below it.
By their numbers in this assay, from the lowest: compounds 1, 3 and 2 (each within the scatter of the next); then compound 4.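

In this assay, 4-methoxyphenyl in place of 2-fluorophenyl on the aromatic nitrogen gives a 13-fold higher number from compound 3 to compound 4 (1.11 log units; beyond the scatter), so the number at this position can depend strongly on the aryl group it carries. The earlier aryl exchange, 4-chlorophenyl in place of 2-fluorophenyl, gave only a 1.5-fold higher number from compound 1 to compound 2 (0.18 log units; within the scatter), which shows that aryl exchanges here are not interchangeable, although that step was read with the methyl amide and this one with the ethyl amide. Nothing available explains the large step.

The compounds shown do not separate the effect of the methoxy group from that of its location on the ring, which 2-methoxyphenyl at this position would address. As far as these compounds go, whether the step carries over to the methyl amide also remains open, as does the response to a 4-hydroxyphenyl or 4-aminophenyl group.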